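The source may report more compounds than this note shows. Statements on the series, on what has been measured and on what is new or still open speak of the compounds shown alone.

Measured in a functional assay on HepG2 cells (Homo sapiens) for antiproliferative activity, with a stated time of 72 h; a higher number here means that more compound is needed for the effect, a lower number that less compound is needed:
- Compound 1 `COc1ccc(-c2cc(=O)c3c(OC)cc(OC)cc3[nH]2)cc1`: > 31100 nM (a limit)
- Compound 2 `COc1ccc(-c2cc(=O)c3c(OC)cc(OC)cc3n2C)cc1`: "not determined" (no result reported)
- Compound 3 `COc1ccc(-c2cc(=O)c3c(OC)cc(OC)cc3n2Cc2ccccc2)cc1`: > 17300 nM (a limit)

Compound 2 has no number of its own in this assay, so its standing can only be judged from the two compounds around it. Neither of these gives a number. Compound 1 stands at > 31100 nM, which is a limit. Compound 3 stands at > 17300 nM, which is also a limit.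

Compound 4 `COC(=O)c1cc(=O)c2c(OC)cc(OC)cc2n1C` departs from compound 2 by methoxycarbonyl in place of 4-methoxyphenyl on an aromatic carbon, with methoxycarbonyl in place of 4-methoxyphenyl on an aromatic carbon, next to the ring nitrogen.

Among the compounds with values here, the one measured step is a step that the two limits leave unreadable from compound 1 to compound 3, with benzyl in place of hydrogen on an aromatic nitrogen. It has no readable size and concerns a different place on the shared core. Within the data shown here, no measured step covers the change to compound 4, so no size or direction can be carried over to this assay. The working expectation is therefore no real gain, with compound 4 staying in the same inactive range as its neighbours and quite possibly reported only as a limit. The estimate for compound 4 is 30000 nM, with an expected range from 12000 nM to 80000 nM.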

Compound 4, half-maximal effective concentration: > 19000 nM
Compound 4: no number, only a limit; the forecaster's own chance of this, stated with the estimate: 75%; the middle value is on the limit's open side.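

No step can be read from compound 2 to compound 4: compound 2 has no number of its own, and in this assay compound 4 gives only a limit, > 19000 nM. The compounds shown leave open what methoxycarbonyl in place of 4-methoxyphenyl does in this assay, and whether any of them reaches a measurable half-maximal effective concentration.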